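This account rests on a few compounds, and the source may have more. Where it says the series, first, only, none or still open, it means among the compounds named here.

In a functional assay on SMMC-7721 cells (Homo sapiens) for inhibition, read by CCK-8 assay, with a stated time of 72 h, tested at 2 uM (on this read-out higher numbers stand for more inhibition of growth at the one concentration tested and lower numbers for less inhibition of growth), compound 1 `Nc1ccccc1NC(=O)/C=C/c1ccc(CSc2ccc(Cl)cc2)cc1` gives 15.2%. That value lies within the usual scatter of compound 3 `Nc1ccccc1NC(=O)c1ccc(CSc2ccc(C(F)(F)F)cn2)cc1` at 12.4%, while compound 2 `COc1ccc(SCc2ccc(C(=O)Nc3ccccc3N)cc2)cc1` reaches 33.1%, a gap beyond the scatter from compound 1. Still unmeasured is compound 4 `CC(C)(C)c1ccc(SCc2ccc(/C=C/C(=O)Nc3ccccc3N)cc2)cc1`, which keeps the core of compound 1 and differs in one place: tert-butyl in place of chloro on an aromatic carbon, para to a large group. Among the measured compounds shown here, no measured pair differing in one place offers a guide, so no step beyond the scatter is expected in this assay, in either direction. The estimated change, a number 1.8 percentage points higher from compound 1 to compound 4 (within the scatter), is therefore small. Compound 4 is expected at 17%, with an estimated range from 5% to 38%.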

Compound 4, percent growth inhibition at one concentration: 18.3%
Compound 4: the middle estimate sits 1.3 percentage points below what was measured; the range from low to high includes it.
By their numbers in this assay, from the lowest: compounds 3, 1 and 4 (each within the scatter of the next); then compound 2.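

In this assay, among the compounds shown here, the step of a number 3.1 percentage points higher from compound 1 to compound 4 (within the scatter) is the first one that can be read at this position, with tert-butyl in place of chloro on an aromatic carbon, para to a large group. On the core of compound 1, this exchange of one chlorine for four carbons leaves the read-out within the scatter. Nothing available gives a reason for this result. Going by these compounds, whether an amine or a carboxylic acid at this position would move the number beyond the scatter remains open. So does whether the same exchange gives a similar step on another core.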